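Notes on compound 4: benzamido on the amide-type nitrogen

The source may report more compounds than this note shows. Statements on the series, on what has been measured and on what is new or still open speak of the compounds shown alone.

In a functional assay on MCF7 cells (Homo sapiens) for antiproliferative activity, read by MTT assay (on this read-out higher numbers stand for weaker inhibition and lower numbers for stronger inhibition), compound 1 `COc1cc2c(Oc3ccc(NC(=O)Nc4ccccc4)cc3)ccnc2cc1OCCCCCCC(=O)NO` gives 1040 nM while compound 2 `COc1cc2c(Oc3ccc(NC(=O)Nc4ccccc4Cl)cc3)ccnc2cc1OCCCCCCC(=O)NO` gives 2780 nM and compound 3 `COc1cc2c(Oc3ccc(NC(=O)Nc4ccc(Cl)c(C(F)(F)F)c4)cc3)ccnc2cc1OCCCCCCC(=O)NO` gives 5150 nM on the same read-out. Compound 3 stands at the high-number end of the three, but it shares that end with one neighbour: the gap a 1.9-fold higher number from compound 2 to compound 3 (0.27 log units; within the scatter) is no real separation. Against the plain phenyl, the gap a 5.0-fold higher number from compound 1 to compound 3 (0.69 log units; beyond the scatter) is modest but real, and a 2.7-fold higher number from compound 1 to compound 2 (0.43 log units; beyond the scatter) is of a similar kind.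

The next compound is compound 4 `COc1cc2c(Oc3ccc(NC(=O)NNC(=O)c4ccccc4)cc3)ccnc2cc1OCCCCCCC(=O)NO` with the difference benzamido in place of 4-chloro-3-(trifluoromethyl)phenyl on an amide-type nitrogen and in words this is benzamido in place of 4-chloro-3-(trifluoromethyl)phenyl on an amide-type nitrogen. Among the measured compounds shown here, no measured compound carries a benzamido group, so the evidence is indirect. For the measured compounds named here, the closest guide is compound 1, whose ring also has no substituent and whose step a 5.0-fold higher number from compound 1 to compound 3 (0.69 log units; beyond the scatter) sets the likely scale in reverse. A modest move towards a lower number is therefore expected, probably short of the full value of compound 1 at 1040 nM given the untested benzamido group. The expected change is a 2.6-fold lower number from compound 3 to compound 4 (0.41 log units; beyond the scatter) as an estimate with wide margins. In this assay the estimate for compound 4 is 2000 nM with an expected range of 800 nM to 5500 nM for a single measurement.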

Compound 4, half-maximal inhibitory concentration: 2450 nM
Compound 4: the middle estimate sits 1.2-fold (0.09 log units) below what was measured; low and high end bracket the measured number.
By their numbers in this assay, from the lowest: compound 1; then compounds 4, 2 and 3 (each within the scatter of the next, the first and the last beyond it).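

In this assay, the group on the amide-type nitrogen need not be a phenyl ring attached directly: benzamido, which enters with a carbonyl and a further nitrogen, gives a 2.1-fold lower number from compound 3 to compound 4 (0.32 log units; beyond the scatter) and so stands clear of the 4-chloro-3-(trifluoromethyl)phenyl group. It does not stand clear of the 2-chlorophenyl group, as a 1.1-fold lower number from compound 2 to compound 4 (0.05 log units; within the scatter) shows no real separation, whereas a 2.4-fold higher number from compound 1 to compound 4 (0.37 log units; beyond the scatter) leaves the plain phenyl of compound 1 with the lowest number of the four and a modest but real margin over benzamido. No measurement of any other property accompanies these numbers, and the steps therefore remain without an explanation.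

Going by these compounds, it remains open whether chloro or trifluoromethyl on the benzamido ring would raise the number as chloro did on the phenyl ring of compound 1, since the ring of compound 4 carries no substituent. Also open, on these data alone, is how far the ring itself matters at this position, which an acetamido group, a pyridine-3-carboxamido group or a benzyl group in place of benzamido would begin to show.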